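This account rests on a few compounds, and the source may have more. Where it says the series, first, only, none or still open, it means among the compounds named here.

Measured in a functional assay on PC-9 cells (Homo sapiens) for inhibition, read by MTT assay, with a stated time of 72 h; a higher number here means a weaker inhibitor, a lower number a stronger inhibitor:
Compound 1 `Cc1cc(Nc2ccn(Cc3cccc4ccccc34)n2)n2nc(SCc3ccc(Br)cc3)nc2n1`: 5660 nM
Compound 2 `Cc1cc(Nc2cc(-c3ccccc3)[nH]n2)n2nc(SCC3CCCCC3)nc2n1`: > 50000 nM
Compound 3 `CCCCCc1c(C)nc2nc(SCc3ccc(Cl)cc3)nn2c1Nc1cc(-c2ccccc2)[nH]n1`: > 50000 nM

Only compound 1 has a measured number. Compound 2 stands at the limit of > 50000 nM in this assay, at which 2 of the 3 values shown sit. On these data alone, its entry is a limit and not a number, so its true position is unknown. The entry for compound 3 is the same kind of limit.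

Compound 4 `Cc1cc(Nc2cc(-c3ccccc3)[nH]n2)n2nc(SCc3ccccc3Br)nc2n1` has not yet been measured in this assay. It keeps the rest of compound 2 and changes one group: 2-bromophenyl in place of cyclohexyl on a saturated chain carbon bound to a sulfur. In words, 2-bromophenyl takes the place of cyclohexyl on a saturated chain carbon bound to a sulfur, which turns cyclohexylmethyl into 2-bromobenzyl.

The other two compounds give only a mixed hint. Compound 1, which also has a bromine-bearing benzyl group on sulfur, gives 5660 nM, although it differs from compound 4 elsewhere too. Compound 3 goes against that hint: it has a chlorine-bearing benzyl group on sulfur, yet it gives > 50000 nM, a limit.

A modest move toward stronger inhibition is therefore expected, and compound 4 may well stay at the limit. The expected step is an at least 1.6-fold lower number from compound 2 to compound 4 (0.22 log units; that floor lies within the scatter).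

For compound 4 the estimate is 30000 nM, with an expected range of 8000 nM to 50000 nM.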

Compound 4, half-maximal inhibitory concentration: 5630 nM
For compound 4 the middle estimate is 5.3-fold (0.73 log units) above the measured one; measured number outside the range, below it.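

In this assay, putting 2-bromophenyl in place of cyclohexyl on a saturated chain carbon bound to a sulfur gives an at least 8.8-fold lower number from compound 2 to compound 4 (0.94 log units; beyond the scatter). This is the first pair shown that differs in one place, so it shows that the group on this carbon alone can move a compound from the limit of the assay to a measured number, which the earlier compounds, all differing in more than one place, could not show. The true size of the step remains unknown, because the entry for compound 2 is a limit and the step is therefore only a floor: the limit of > 50000 nM in this assay, at which 2 of the 4 values shown sit.

The ring and the bromine arrive together in this single change, so the compounds shown do not separate what the aromatic ring contributes from what the bromine contributes. On these data alone, it also stays open how the number would respond to a plain benzyl group on the sulfur, or to an amine or a carboxylic acid in place of the bromine, and whether the same change would have a similar effect on a different core.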